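Replacing the amide hydrogen of compound 3 with 3-methoxyphenyl

A few compounds are considered here, and "the series" means these few. Any claim that something is new, unique, unknown or untested is made for them only; others in the source may bear on it.

Compound 3 `NC(=S)N/N=C/c1ccc2ccccc2n1` carries a free amide nitrogen on the thiocarbonyl. In a functional assay on SGC-7901 cells (Homo sapiens) for antiproliferative activity, read by sulforhodamine B assay, with a stated time of 72 h (a higher number here means a weaker inhibitor, a lower number a stronger inhibitor), compound 3 gives 32700 nM. Among the measured compounds shown here, of the two numbers known, its value and that of compound 2 lie within the scatter of each other, and the third value is a limit. Compound 2 `N#Cc1ccc(NC(=S)N/N=C/c2ccc3ccccc3n2)cc1` bears a 4-cyanophenyl on that nitrogen, and in this assay compound 2 gives 23700 nM; the step of a 1.4-fold higher number from compound 2 to compound 3 (0.14 log units; within the scatter) shows no real difference. Compound 1 `Fc1ccccc1NC(=S)N/N=C/c1ccc2ccccc2n1` bears a 2-fluorophenyl there. In this assay compound 1 reaches only the limit > 100000 nM, which is a limit of the assay (the limit of > 100000 nM in this assay, at which 1 of the 3 values shown sits). The step of an at least 3.0-fold lower number from compound 1 to compound 3 (0.48 log units; beyond the scatter) is at least modest, as is an at least 4.2-fold lower number from compound 1 to compound 2 (0.62 log units; beyond the scatter).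

Compound 4 `COc1cccc(NC(=S)N/N=C/c2ccc3ccccc3n2)c1` differs from compound 3 by 3-methoxyphenyl in place of hydrogen on an amide-type nitrogen. The two aryl replacements of that hydrogen seen so far gave one result within the scatter and one that fell to the limit, so compound 4 is expected to be near compound 3 or somewhat weaker, a step estimated as a 1.4-fold higher number from compound 3 to compound 4 (0.14 log units; within the scatter). In this assay compound 4 is expected to give 45000 nM, with a range from 15000 nM to 150000 nM.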

Compound 4, half-maximal inhibitory concentration: 79400 nM
Beside the measured number, compound 4's estimate is 1.8-fold (0.25 log units) below it; low and high end bracket the measured number.
By their numbers in this assay, from the lowest: compounds 2 and 3 (each within the scatter of the next); then compound 4. At a limit, above all of these: compound 1.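

With 3-methoxyphenyl on the amide-type nitrogen, an aryl replacement of the hydrogen now carries a cost that can be sized as a number, a 2.4-fold higher number from compound 3 to compound 4 (0.39 log units; beyond the scatter), whereas the 4-cyanophenyl of compound 2 could not be told from hydrogen. The two aryl groups also separate from each other, with a 3.4-fold higher number from compound 2 to compound 4 (0.53 log units; beyond the scatter), so this nitrogen does not treat all aryl groups alike. The step of an at least 1.2-fold lower number from compound 1 to compound 4 (0.10 log units; that floor lies within the scatter) does not separate these two compounds, and compound 1 stands at a limit of the assay rather than at a number: the limit of > 100000 nM in this assay, at which 1 of the 4 values shown sits.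

The compounds shown leave open whether the substituent on the phenyl ring or its position accounts for these differences, as the three aryl groups differ in both. They also leave open how a simple methyl group, a longer alkyl chain or a chain ending in an amine on this nitrogen would compare with hydrogen.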